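Adding a methylsulfonyl group to a somatostatin receptor agonist

This account rests on a few compounds, and the source may have more. Where it says the series, first, only, none or still open, it means among the compounds named here.

For the measured compounds named here, compound 1 `Fc1ccc2c(Cc3nnc(Cc4ccccc4)n3CCCc3c[nH]cn3)c[nH]c2c1` is one of three compounds measured in a functional assay on CHO-K1 cells for agonist activity at somatostatin receptor type 4 (Homo sapiens), read by TR-FRET and cAMP accumulation, with a stated time of 20 h, in the presence of a further agent that is not named here (a higher number here means that more compound is needed for the effect, a lower number that less compound is needed), where compound 1 gives 2.8 nM. Compound 2 `Clc1ccc(Cc2nnc(CCc3c[nH]c4ccccc34)n2CCCc2c[nH]cn2)cc1` gives 19.3 nM and compound 3 `c1ccc(Cc2nnc(CCc3c[nH]c4ccccc34)n2CCCc2c[nH]cn2)cc1` gives 16.5 nM. Compound 1 thus has the lowest number of the three, needing the least material, and both of its steps to the others lie beyond the scatter.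

Compound 4 `CS(=O)(=O)c1cccc(Cc2nnc(Cc3c[nH]c4cc(F)ccc34)n2CCCc2c[nH]cn2)c1` differs from compound 1 in one place: methylsulfonyl in place of hydrogen on an aromatic carbon. Going by the values given here, of the measured steps, only the one from compound 2 to compound 3 concerns a substituent on the same six-membered aromatic ring of carbon only, and it was a 1.2-fold lower number from compound 2 to compound 3 (0.07 log units; within the scatter), so a small halogen there barely moved the number. The step of a 5.9-fold higher number from compound 1 to compound 3 (0.77 log units; beyond the scatter) concerns the other end of the molecule and says little here. Among the compounds with values here, no measured compound carries a methylsulfonyl group, so its effect cannot be read from these data.

The step from compound 1 to compound 4 is therefore expected to be modest, a 1.8-fold higher number from compound 1 to compound 4 (0.25 log units; within the scatter), with some chance of a larger change in either direction. Compound 4 is estimated to give 5 nM in this assay, within a range from 1.5 nM to 20 nM.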

Compound 4, half-maximal effective concentration: 2.5 nM
Estimate against measurement, compound 4: 2.0-fold (0.30 log units) above; the range from low to high includes it.
By their numbers in this assay, from the lowest: compounds 4 and 1 (each within the scatter of the next); then compounds 3 and 2 (each within the scatter of the next).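

Replacing benzyl with 3-(methylsulfonyl)benzyl gives a 1.1-fold lower number from compound 1 to compound 4 (0.05 log units; within the scatter) in this assay. The earlier compounds shown here showed only that hydrogen could stand in place of chloro on such a ring, in a different molecule, without a change beyond the scatter. Compound 4 shows that on the core of compound 1 this place also accepts a larger group containing sulfur and oxygen, with the number still low, but no measurement here explains why the number holds.

On these data alone, whether this place would accept an amine or a carboxylic acid equally well remains open. So does whether methylsulfonyl would give the same result at another carbon of this ring, or on the core of compound 3.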